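Methyl on the piperidine ring: compound 3 toward compound 4

A few compounds are considered here, and "the series" means these few. Any claim that something is new, unique, unknown or untested is made for them only; others in the source may bear on it.

Measured in a functional assay on NCI-H460 cells (Homo sapiens) for inhibition, read by MTT assay, with a stated time of 72 h; a lower number here means a stronger inhibitor, a higher number a weaker inhibitor:
- compound 1 `COc1cc2c(Oc3ccc(NC(=O)c4nn(-c5ccccc5C(F)(F)F)c(=O)cc4C)cc3F)ccnc2cc1OCCCN1CCC(C)CC1`: 200 nM
- compound 2 `COc1cc2c(Oc3ccc(NC(=O)c4nn(-c5cccc(F)c5)c(=O)cc4C)cc3F)ccnc2cc1OCCCN1CCC(C)CC1`: 250 nM
- compound 3 `COc1ccc(-n2nc(C(=O)Nc3ccc(Oc4ccnc5cc(OCCCN6CCCCC6)c(OC)cc45)c(F)c3)c(C)cc2=O)cc1`: 3730 nM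

Compound 3 gives the highest number of the three in this assay, beyond the scatter from both compound 2 and compound 1. Going by the values given here, the only single-point step among the measured compounds is a 1.3-fold higher number from compound 1 to compound 2 (0.10 log units; within the scatter), which concerns the aryl group on the aromatic nitrogen and not the saturated ring.

Compound 4 `COc1ccc(-n2nc(C(=O)Nc3ccc(Oc4ccnc5cc(OCCCN6CCC(C)CC6)c(OC)cc45)c(F)c3)c(C)cc2=O)cc1` differs from compound 3 by methyl in place of hydrogen on a saturated ring carbon. Among the compounds with values here, no measured pair isolates this change: compound 1 and compound 2 carry the methylated ring, compound 3 the unsubstituted one, but they also differ in the aryl group on the aromatic nitrogen, so their gaps cannot be split between the two changes. Within the data shown here, with no step bearing directly on it, a step of no more than the scatter is expected in this assay from compound 3 to compound 4, that is a 1.2-fold lower number from compound 3 to compound 4 (0.09 log units; within the scatter). Compound 4 is therefore estimated at 3000 nM, within 1200 nM to 7500 nM.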

Compound 4, half-maximal inhibitory concentration: 4650 nM
For compound 4 the middle estimate is 1.6-fold (0.19 log units) below the measured one; the range from low to high includes it.
By their numbers in this assay, from the lowest: compounds 1 and 2 (each within the scatter of the next); then compounds 3 and 4 (each within the scatter of the next).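

In this assay, going by these compounds alone, the change from piperidin-1-yl to 4-methylpiperidin-1-yl gives a 1.2-fold higher number from compound 3 to compound 4 (0.10 log units; within the scatter) with the 4-methoxyphenyl group held on the aromatic nitrogen, so this ring carbon now has a direct reading, one the earlier compounds could not separate from the aryl change. With 4-methylpiperidin-1-yl held, the large steps belong to the aryl group: 4-methoxyphenyl in place of 3-fluorophenyl gives a 19-fold higher number from compound 2 to compound 4 (1.27 log units; beyond the scatter) and 4-methoxyphenyl in place of 2-(trifluoromethyl)phenyl gives a 23-fold higher number from compound 1 to compound 4 (1.37 log units; beyond the scatter) on the same saturated ring. No measured evidence accounts for the size of any of these steps.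

The compounds shown leave open whether methyl in place of hydrogen reads the same with 3-fluorophenyl or 2-(trifluoromethyl)phenyl on the aromatic nitrogen. Also open, as far as these compounds go, is how a hydroxyl, an ethyl or a carboxylic acid at this ring carbon would read.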